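Cytotoxicity of cyclopentyl uracil nucleoside analogues on leukaemia cells

The source may report more compounds than this note shows. Statements on the series, on what has been measured and on what is new or still open speak of the compounds shown alone.

Compound 1: `O=c1[nH]c(=O)n([C@@H]2CCC[C@H]2CO)cc1I` — > 200000 nM
Compound 2: `O=c1ccn([C@@H]2CCC[C@H]2CO)c(=O)[nH]1` — > 200000 nM
Compound 3: `O=c1[nH]c(=O)n([C@@H]2C[C@H](CO)C[C@@H]2CO)cc1I` — > 200000 nM

In an ADME assay on L1210/0 cells (Mus musculus) for cytotoxicity, with a stated time of 48 h (a lower number here means a stronger inhibitor, a higher number a weaker inhibitor), compound 1 gives only a limit of the assay, > 200000 nM. Compound 2 likewise gives only a limit, > 200000 nM. Compound 3 also gives only a limit, > 200000 nM. The change from compound 1 to compound 2 is hydrogen in place of iodo on an aromatic carbon; its step, a step that the two limits leave unreadable from compound 1 to compound 2, cannot be read because of the limit of > 200000 nM in this assay, at which 3 of the 3 values shown sit. The difference between the core of compound 1 and that of compound 3 is not broken down here.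

Compound 4, `O=c1ccn([C@@H]2C[C@H](CO)C[C@@H]2CO)c(=O)[nH]1`, is not yet measured; it arises from compound 3 by hydrogen in place of iodo on an aromatic carbon, the same kind of change, the place being meta to a group of 9 heavy atoms rather than 7. Since compound 3 gives only a limit, > 200000 nM, compound 4 is expected to stay at the limit too, a step that the limit leaves unreadable from compound 3 to compound 4. The estimate for compound 4 is 300000 nM, between 150000 nM and 1000000 nM.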

Compound 4, half-maximal inhibitory concentration: > 200000 nM
Compound 4 was reported as a limit; the forecaster's own chance of this, stated with the estimate: 90%; the middle value does not contradict the limit.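

No new step can be read from compound 3 to compound 4, because both compounds give only a limit: the limit of > 200000 nM in this assay, at which 4 of the 4 values shown sit. The compounds shown leave open how iodo and hydrogen, or the two cores, compare in this assay.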